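Compound 4: the hydroxycarbamoyl group moved on the phenyl

The source may report more compounds than this note shows. Statements on the series, on what has been measured and on what is new or still open speak of the compounds shown alone.

Compound 1 `O=C(NO)c1cccc(NCCOc2ccc3cc2COC/C=C/COCc2cccc(c2)-c2ccnc(n2)N3)c1` carries a (3-(hydroxycarbamoyl)phenyl)amino group on the chain that leaves the aromatic oxygen of the shared core. In a functional assay on MDA-MB-231 cells (Homo sapiens) for antiproliferative activity, read by MTT assay, with a stated time of 72 h (a higher number here means a weaker inhibitor, a lower number a stronger inhibitor), compound 1 gives > 50000 nM, which is a limit of the assay and not a number. Two measured neighbours carry acids in place of that group: compound 2 `O=C(O)CCCCCCOc1ccc2cc1COC/C=C/COCc1cccc(c1)-c1ccnc(n1)N2` gives 12000 nM in this assay, and compound 3 `O=C(O)CCCCCOc1ccc2cc1COC/C=C/COCc1cccc(c1)-c1ccnc(n1)N2` gives 19900 nM. The step of an at least 4.1-fold lower number from compound 1 to compound 2 (0.61 log units; beyond the scatter) and the step of an at least 2.5-fold lower number from compound 1 to compound 3 (0.40 log units; beyond the scatter) both move away from the limit, while between the two acids the step of a 1.7-fold higher number from compound 2 to compound 3 (0.22 log units; within the scatter) is small.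

Compound 4 `O=C(NO)c1ccc(NCCOc2ccc3cc2COC/C=C/COCc2cccc(c2)-c2ccnc(n2)N3)cc1` keeps every atom of compound 1 and differs only in 4-(hydroxycarbamoyl)phenyl in place of 3-(hydroxycarbamoyl)phenyl on an amine nitrogen. Going by the values given here, none of the measured steps touches this change: each of them replaces the whole hydroxycarbamoyl-bearing group rather than relocating it, so the measured steps give no direction for the step to compound 4. Since compound 1 stands only at the limit, the estimate for compound 4 rests on an open range. Compound 4 is expected at 10000 nM, between 1500 nM and 60000 nM. That estimate means an expected step of an at least 5.0-fold lower number from compound 1 to compound 4 (0.69 log units; beyond the scatter), with a real chance that the result is again reported only as a limit.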

Compound 4, half-maximal inhibitory concentration: 8690 nM
Beside the measured number, compound 4's estimate is 1.2-fold (0.06 log units) above it; the measured number falls inside the stated range.
By their numbers in this assay, from the lowest: compounds 4, 2 and 3 (each within the scatter of the next, the first and the last beyond it). At a limit, above all of these: compound 1.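

Going by these compounds alone, the step of an at least 5.7-fold lower number from compound 1 to compound 4 (0.75 log units; beyond the scatter) shows that in this assay this position on the phenyl matters: relocating the hydroxycarbamoyl group on the amine nitrogen, with no atom gained or lost, gives the only number for a hydroxycarbamoyl-bearing group. Against the two acids, the step of a 2.3-fold lower number from compound 3 to compound 4 (0.36 log units; beyond the scatter) is beyond the scatter, while the step of a 1.4-fold lower number from compound 2 to compound 4 (0.14 log units; within the scatter) is within it, so the (4-(hydroxycarbamoyl)phenyl)amino group of compound 4 and the 4-carboxybutyl group of compound 2 cannot be put in order. The value of compound 1 is a limit and not a number, so the step from it has no upper end: the limit of > 50000 nM in this assay, at which 1 of the 4 values shown sits.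

Open, as far as these compounds go, is whether a longer saturated chain leading to the amine nitrogen would keep the number of compound 4, and whether a carboxylic acid in place of the hydroxycarbamoyl group on the same phenyl would read the same way. Also open, from the compounds shown here alone, is whether a primary amide at that place would separate from compound 4 by more than the scatter.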